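This account rests on a few compounds, and the source may have more. Where it says the series, first, only, none or still open, it means among the compounds named here.

Compound 2 `CC1(C)S[C@@H]2/C(=C\C(=O)c3ccc(Cl)cc3)C(=O)N2[C@H]1C(=O)OC(c1ccccc1)c1ccccc1`: 48600 nM
Compound 1 `CC1(C)S[C@@H]2/C(=C\C(=O)c3cc(C(F)(F)F)cc(C(F)(F)F)c3)C(=O)N2[C@H]1C(=O)OC(c1ccccc1)c1ccccc1`: 39200 nM

Of the compounds shown here, two sharing one core have been measured in a functional assay on A-375 cells (Homo sapiens) for cytotoxicity, read by MTT assay, with a stated time of 48 h; on this read-out lower numbers stand for stronger inhibition and higher numbers for weaker inhibition. Compound 2 `CC1(C)S[C@@H]2/C(=C\C(=O)c3ccc(Cl)cc3)C(=O)N2[C@H]1C(=O)OC(c1ccccc1)c1ccccc1` gives 48600 nM and stands at the highest of the two numbers, yet compound 1 `CC1(C)S[C@@H]2/C(=C\C(=O)c3cc(C(F)(F)F)cc(C(F)(F)F)c3)C(=O)N2[C@H]1C(=O)OC(c1ccccc1)c1ccccc1` gives 39200 nM, a value within the scatter of compound 2, so the two cannot be told apart on this read-out. Compound 3 `CC1(C)S[C@@H]2/C(=C\C(=O)c3ccc([N+](=O)[O-])cc3)C(=O)N2[C@H]1C(=O)OC(c1ccccc1)c1ccccc1` has not yet been measured. It differs from compound 2 in one place: nitro in place of chloro on an aromatic carbon. For the measured compounds named here, no step between measured compounds is known for this kind of change, and the shared core so far shows only weak inhibition in this assay. Compound 3 is therefore expected to show a step of a 1.1-fold lower number from compound 2 to compound 3 (0.03 log units; within the scatter) that stays within the scatter, in no clear direction. For compound 3 the value in this assay is estimated at 45000 nM, within a range from 20000 nM to 100000 nM.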

Compound 3, half-maximal inhibitory concentration: 50300 nM
The estimate for compound 3 lay 1.1-fold (0.05 log units) below the measured number, within the range that was stated.
By their numbers in this assay, from the lowest: compounds 1, 2 and 3 (each within the scatter of the next).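

In this assay, for the compounds shown here, the exchange of chloro for nitro on the aromatic carbon para to a large group gives a 1.0-fold higher number from compound 2 to compound 3 (0.01 log units; within the scatter), the first step that can be read at this position. Chloro brings 0 hydrogen-bond acceptors and nitro brings 2, yet this read-out does not tell compound 2 and compound 3 apart, so this exchange leaves the weak inhibition of the shared core in place. Nothing at hand accounts for this result.

As far as these compounds go, it remains open whether an amine or a methoxy group on the same aromatic carbon would give a step beyond the scatter. From the compounds shown here alone, it also remains open whether the step from chloro to nitro would look the same if a free carboxylic acid took the place of the ester.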